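The source may report more compounds than this note shows. Statements on the series, on what has been measured and on what is new or still open speak of the compounds shown alone.

Measured so far in an assay on isolated protein for inhibition of eIF-2-alpha kinase GCN2 (Homo sapiens); a higher number here means a weaker inhibitor, a lower number a stronger inhibitor:

compound 1, `CCn1cc(Nc2ncc3c(C)nn(-c4ccc(C#N)cc4)c3n2)cn1`, gives 56 nM
compound 2, `COCCNC(=O)[C@H]1CC[C@@H](Nc2ncc3c(Br)nn(-c4ccc5ncccc5c4)c3n2)C1`, gives 61 nM

Among the measured compounds shown here, the two numbers lie within the usual scatter of each other, so on these values nothing separates compound 2 from compound 1; compound 2 is simply the one whose number is nearer the top of this short list.

Compound 3, `COCCNC(=O)[C@@H]1CC[C@H](Nc2ncc3c(Br)nn(-c4ccc5ncccc5c4)c3n2)C1`, is the unmeasured partner of compound 2. The change is the two compounds have the same atoms and bonds and differ only in configuration as drawn: 2 of 2 stereo elements differ (all stereocentres are inverted: mirror images); a stereocentre at a saturated ring carbon is drawn S in compound 2 and R in compound 3; a stereocentre at a saturated ring carbon is drawn R in compound 2 and S in compound 3. Nothing leaves and nothing enters; the two compounds are mirror images of each other.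

For the measured compounds named here, no measured pair in this set shows what inverting both stereocentres does, so there is no step to lean on. For a pair of mirror images a gap beyond the scatter in this assay is the more usual outcome than a gap within it, and the direction cannot be read from the two values given. The working expectation is that compound 3 gives a higher number than compound 2, with wide uncertainty, the expected step being a 4.1-fold higher number from compound 2 to compound 3 (0.61 log units; beyond the scatter). On that basis compound 3 is estimated at 250 nM, within a range of 40 nM to 2500 nM.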

Compound 3, half-maximal inhibitory concentration: 923 nM
Compound 3: middle estimate off by 3.7-fold (0.57 log units), on the low side; low and high end bracket the measured number.
By their numbers in this assay, from the lowest: compounds 1 and 2 (each within the scatter of the next); then compound 3.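

In this assay, among the compounds shown here, inverting both stereocentres at the saturated ring carbons gives a 15-fold higher number from compound 2 to compound 3 (1.18 log units; beyond the scatter), the first reading of what configuration at this ring is worth. With no group leaving or entering, the whole step goes with the spatial arrangement, because the pair offers nothing else to which it could be assigned: the fact that compounds 2 and 3 differ only in the configuration as drawn. The saturated ring is therefore not indifferent to how its two substituents are drawn, and of these two mirror images the arrangement in compound 2 is the one that gives the lower number in this assay, so any further reading at this position has to specify configuration.

Since both stereocentres change together, this pair cannot show how much of the step belongs to each one, a question that only a compound with a single stereocentre inverted, keeping the same atoms and bonds, could settle. It also leaves open whether the same preference for one mirror image holds when the methoxyethyl amide gives way to a carboxylic acid or when the bromine gives way to chlorine.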